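The source may hold more compounds than are shown below. What is called first, only, known or untested is meant among the compounds shown, and "the series" means these compounds.

Measured compounds and values:
compound 1, `CCOC(=O)[C@@]1(O)OC(=O)C(Cc2ccc3c(c2)CCC(C)(C)O3)=C1c1ccc(O)cc1`: 519000 nM
compound 2, `COC(=O)[C@@]1(O)OC(=O)C(Cc2ccc3c(c2)CCC(C)(C)O3)=C1c1ccc(O)cc1`: 278000 nM

Both compounds were tested in an ADME assay on Caco-2 cells (Homo sapiens) for cytotoxicity, read by MTT assay, with a stated time of 72 h; a lower number here means that less compound is tolerated, a higher number that more compound is tolerated. Going by the values given here, on these two numbers, compound 2 holds the lower value, but its only neighbour is compound 1, and the step of a 1.9-fold lower number from compound 1 to compound 2 (0.27 log units; within the scatter) lies within the scatter, so the two values cannot be told apart. Compound 3, `CC1(C)CCc2cc(CC3=C(c4ccc(O)cc4)[C@@](O)(C(=O)O)OC3=O)ccc2O1`, has not yet been measured in this assay. It differs from compound 2 by hydrogen in place of methyl on an oxygen next to a carbonyl group. Among the compounds with values here, the only measured step that bears on this change is the one from compound 1 to compound 2, which also trimmed the group on the oxygen next to a carbonyl group and gave a 1.9-fold lower number from compound 1 to compound 2 (0.27 log units; within the scatter), a step within the scatter. Here the remaining methyl is removed altogether, so that methoxycarbonyl becomes carboxy; no measured compound shows what that does in this assay. The expectation for compound 3 is therefore a step of no more than the scatter, a 1.2-fold higher number from compound 2 to compound 3 (0.06 log units; within the scatter). Compound 3 is estimated at 320000 nM, with a range from 120000 nM to 850000 nM.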

Compound 3, half-maximal cytotoxic concentration: > 800000 nM
Compound 3: a limit, no number; the forecaster's own chance of this, stated with the estimate: 25%; middle value at least 2.5-fold (0.39 log units) from the limit.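

In this assay, going by these compounds alone, hydrogen in place of methyl on an oxygen next to a carbonyl group turns methoxycarbonyl into carboxy and gives an at least 2.8-fold higher number from compound 2 to compound 3 (0.45 log units; beyond the scatter), so more compound is tolerated, and this is the first step at this position that clears the scatter. Shortening ethyl to methyl had given a 1.9-fold lower number from compound 1 to compound 2 (0.27 log units; within the scatter), which is no readable difference, whereas removing the group altogether does register against methyl, although against ethyl the result is only an at least 1.5-fold higher number from compound 1 to compound 3 (0.18 log units; that floor lies within the scatter), a floor that cannot yet be told from the scatter. Compound 3 stands at a limit of the assay, not at a number, so both steps from it are minimum sizes and their true sizes remain unknown: the limit of > 800000 nM in this assay, at which 1 of the 3 values shown sits.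

On these data alone, how far the tolerated concentration of compound 3 really extends stays open, and with it how large the gain over the two esters is. Also open, as far as these compounds go, is whether this gain belongs to the carboxy group itself or would also appear with a primary amide in its place, or with a longer chain such as propyl on the same oxygen.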